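Benzyl for Phenyl on a Nucleotide at the Limit

The source may hold more compounds than are shown below. What is called first, only, known or untested is meant among the compounds shown, and "the series" means these compounds.

Compound 1 `COc1ccc(C(=O)O[C@@H]2[C@H](OC(=O)c3ccc(OC)cc3)[C@@H](COP(=O)(O)OP(=O)(O)OP(=O)(O)O)O[C@H]2n2cnc3c(N)ncnc32)cc1` and compound 2 `O=P(O)(O)OP(=O)(O)OP(=O)(O)OC[C@H]1O[C@@H](n2cnc3c(Nc4ccccc4)ncnc32)[C@H](O)[C@@H]1O` were both tested in an assay on HEK293 cells for agonist activity at P2X purinoceptor 7 (Homo sapiens), read by calcium flux, with stated times of 1 h and 30 min, in the presence of a further agent that is not named here; a higher number here means a weaker inhibitor, a lower number a stronger inhibitor. In this assay compound 1 gives > 100000 nM, which is a limit of the assay rather than a number. Compound 2 likewise gives > 100000 nM, again a limit and not a measured number. Both results sit at the same point, as the limit of > 100000 nM in this assay, at which 2 of the 2 values shown sit, records, so compound 2 stands where no inhibition could be quantified at all. Compound 3 `O=P(O)(O)OP(=O)(O)OP(=O)(O)OC[C@H]1O[C@@H](n2cnc3c(NCc4ccccc4)ncnc32)[C@H](O)[C@@H]1O` is built from compound 2 by benzyl in place of phenyl on a nitrogen on an aromatic ring. Among the compounds with values here, no measured step between two compounds exists here, so there is no precedent for the size of this change. With both measured compounds at the limit, the expected step is none beyond the scatter, a step that the limit leaves unreadable from compound 2 to compound 3. Compound 3 is therefore estimated at about 150000 nM, within 50000 nM to 500000 nM, and most likely reported again as a limit.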

Compound 3, half-maximal inhibitory concentration: > 100000 nM
Compound 3 ended at the assay's limit (the forecaster's own chance of this, stated with the estimate: 80%); the middle value is on the limit's open side.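

In this assay compound 3 gives > 100000 nM, which is a limit of the assay and not a number. Within the data shown here, no step from compound 2 to compound 3 can therefore be read: the limit of > 100000 nM in this assay, at which 3 of the 3 values shown sit. The compounds shown leave open whether benzyl and phenyl on that nitrogen differ in inhibition at all.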